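The source may hold more compounds than are shown below. What is called first, only, known or untested is meant among the compounds shown, and "the series" means these compounds.

Measured so far in an assay on isolated protein for inhibition of MAP kinase-activated protein kinase 2 (Homo sapiens), read by HTRF, tested at 10 uM; a higher number here means more inhibition at the concentration tested (going by the name of the read-out), a lower number less inhibition:

Compound 1 `CN(CCCn1ccnc1)C(=O)[C@@H]1CCCN1c1nccc(Nc2ccccc2)n1`: 2%
Compound 2 `O=C(CN1CCN(c2ncnc3c2CN(Cc2ccccc2)CC3)CC1)Nc1cc(F)ccc1F`: 0%

Compound 1 gives 2% and compound 2 gives 0%; the two numbers lie within the usual scatter of each other, so neither compound can be said to inhibit more than the other, and neither shows inhibition that stands apart from the noise of the measurement. The two compounds also have different cores, so no single structural change between measured compounds is available to show how one alteration moves the read-out.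

Compound 3 `CN(C)CC(C)(C)CNC(=O)[C@@H]1CCCN1c1nccc(Nc2ccccc2)n1` has not yet been measured. It keeps the core of compound 1 and differs from it in one place:
(2-((dimethylamino)methyl)-2-methylpropyl)amino in place of (3-(1H-imidazol-1-yl)propyl)(methyl)amino on a carbonyl carbon
Among the measured compounds shown here, with compound 1 at 2% and no measured step to lean on, the plainest expectation is that exchanging one side chain for another on an otherwise unchanged compound leaves the read-out near that number. Compound 3 is therefore expected to give about 2%, with a range from -8% to 12%. The expected step is no change at the digits printed from compound 1 to compound 3 (within the scatter), none beyond the scatter.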

Compound 3, a percentage reported as inhibition, at one concentration (the size of the read-out at that concentration, not a potency): 4%
Beside the measured number, compound 3's estimate is 2 percentage points below it; the range from low to high includes it.
By their numbers in this assay, from the lowest: compounds 2, 1 and 3 (each within the scatter of the next).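

In this assay, replacing (3-(1H-imidazol-1-yl)propyl)(methyl)amino with (2-((dimethylamino)methyl)-2-methylpropyl)amino on the carbonyl carbon gives a number 2 percentage points higher from compound 1 to compound 3 (within the scatter). This swap removes the five-membered aromatic ring and brings in a side chain with no ring and 1 hydrogen-bond donor, yet the read-out shows no change that can be told apart from the scatter, so this position now has its first direct comparison and that comparison shows no difference between these two side chains. No separate measurement is available to explain this result.

With both compounds so close to the bottom of the scale, these two side chains cannot show whether this position matters for inhibition, since a real effect could be hidden when neither compound inhibits to a clear extent. From the compounds shown here alone, it remains open whether a different group on the same carbonyl carbon, such as a carboxylic acid, a benzylamine or a longer chain ending in a morpholine, would give a read-out that stands clearly above the scatter.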